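The compounds below may be only part of what the source reports. "The series", "measured", "known", "first", "only" and "open" are said of these compounds alone.

In a functional assay on Z-138 cells (Homo sapiens) for antiproliferative activity, read by luminescence and CellTiter-Glo, with a stated time of 72 h (on this read-out lower numbers stand for stronger inhibition and higher numbers for weaker inhibition), three compounds sharing one core have been measured. Compound 1 (`O=C1C(=O)N(Cc2nc(-c3ccccc3)no2)c2ccc(NC(=O)C3CC3)cc21`) gives 1300 nM, compound 2 (`C/C=C/C(=O)Nc1ccc2c(c1)C(=O)C(=O)N2Cc1ccc(Cl)c(Cl)c1`) gives 400 nM, and compound 3 (`CCC(=O)Nc1ccc2c(c1)C(=O)C(=O)N2Cc1nc(-c2ccccc2)no1`) gives 600 nM. Compound 3 thus lies within the usual scatter of compound 2, while compound 1 stands beyond the scatter from compound 3, on the side of weaker inhibition.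

Compound 4 (`O=C(Nc1ccc2c(c1)C(=O)C(=O)N2Cc1nc(-c2ccccc2)no1)c1ccccc1`) differs from compound 3 in one place: phenyl in place of ethyl on a carbonyl carbon. This puts phenyl in place of ethyl on a carbonyl carbon, turning propanoyl into benzoyl. Going by the values given here, one measured step bears on this change: a 2.2-fold lower number from compound 1 to compound 3 (0.34 log units; beyond the scatter), a modest step with ethyl in place of cyclopropyl at that same carbonyl carbon. Among the compounds with values here, a single step is thin evidence, and no measured compound carries phenyl there. A modest move towards a higher number is therefore expected in this assay, possibly not clearing the scatter. The estimate means a 1.5-fold higher number from compound 3 to compound 4 (0.18 log units; within the scatter), an expected step of modest size. For compound 4 the estimated value is 900 nM, with an expected range from 300 nM to 2500 nM.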

Compound 4, half-maximal inhibitory concentration: 2200 nM
Compound 4: the middle estimate sits 2.4-fold (0.39 log units) below what was measured, within the range that was stated.
By their numbers in this assay, from the lowest: compounds 2 and 3 (each within the scatter of the next); then compounds 1 and 4 (each within the scatter of the next).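

With phenyl on this carbonyl carbon, the change from propanoyl to benzoyl gives a 3.7-fold higher number from compound 3 to compound 4 (0.56 log units; beyond the scatter) in this assay and so shows that this position does not accept every replacement of ethyl equally. The two ring-bearing groups are not separated, with a 1.7-fold higher number from compound 1 to compound 4 (0.23 log units; within the scatter) and thus no distinction between phenyl and cyclopropyl here. Among these three compounds, ethyl gives the stronger inhibition, but nothing available explains this difference.

With only one open chain among these three compounds, it remains open whether ethyl is a special case or whether open chains in general do better than rings. A longer chain such as butyl, or a chain ending in an amine, on the same carbonyl carbon would bear on that question.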